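The source may report more compounds than this note shows. Statements on the series, on what has been measured and on what is new or still open speak of the compounds shown alone.

Three compounds share a common core and differ in two places. In a functional assay on CEM-DNR-bulk cells (Homo sapiens), read by MTT assay, with a stated time of 72 h (a higher number here means a weaker inhibitor, a lower number a stronger inhibitor), compound 1 `CNc1ncnc2c1c(-c1ccsc1)cn2[C@@H]1O[C@H](CO)[C@@H](O)[C@H]1O` reaches only the limit of the assay, > 20000 nM. For the measured compounds named here, compound 2 `Cc1ncnc2c1c(-c1ccsc1)cn2[C@@H]1O[C@H](CO)[C@@H](O)[C@H]1O` gives 8560 nM in this assay, and the step of an at least 2.3-fold lower number from compound 1 to compound 2 (0.36 log units; beyond the scatter) is the only measured change in the set. Compound 3 `CSc1ncnc2c1c(-c1cccs1)cn2[C@@H]1O[C@H](CO)[C@@H](O)[C@H]1O` also yields no number in this assay but only the limit, > 20000 nM; this is the limit of > 20000 nM in this assay, at which 2 of the 3 values shown sit. Compound 4 `CSc1ncnc2c1c(-c1ccsc1)cn2[C@@H]1O[C@H](CO)[C@@H](O)[C@H]1O` differs from compound 3 by thiophen-3-yl in place of thiophen-2-yl on an aromatic carbon. Going by the values given here, no measured step touches this exchange, and the one step that exists is at least modest and concerns another position. The expected change is a number no higher from compound 3 to compound 4 (the limit leaves the size open), within the scatter. Compound 4 is estimated at 20000 nM, between 8000 nM and 50000 nM.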

Compound 4, half-maximal inhibitory concentration: > 20000 nM
Compound 4: no number, only a limit; the forecaster's own chance of this, stated with the estimate: 70%; the middle value sits exactly at the limit.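

Methylsulfanyl in place of methyl gives an at least 2.3-fold higher number from compound 2 to compound 4 (0.36 log units; beyond the scatter) in this assay, so with thiophen-3-yl held fixed, methyl is the only one of the three groups on this aromatic carbon that yields a number. Compound 4 itself gives only a limit, > 20000 nM. The steps from compound 3 to compound 4 and from compound 1 to compound 4 cannot be read: the limit of > 20000 nM in this assay, at which 3 of the 4 values shown sit.

From the compounds shown here alone, the effect of exchanging thiophen-2-yl for thiophen-3-yl therefore stays open. So does whether an ethyl or a methoxy group on this carbon would give a number like that of compound 2.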